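A few compounds are considered here, and "the series" means these few. Any claim that something is new, unique, unknown or untested is made for them only; others in the source may bear on it.

In a functional assay on HepG2 cells (Homo sapiens) for antiproliferative activity, read by MTT assay, with a stated time of 24 h (a higher number here means a weaker inhibitor, a lower number a stronger inhibitor), compound 1 `COc1ccc(C(=O)/C=C/c2ccc([N+](=O)[O-])cc2)c2c1C=CC(C)(C)O2` gives a measured number, 2610 nM. Compound 2 `COc1ccc(C(=O)/C=C/c2ccsc2)c2c1C=CC(C)(C)O2` gives only a limit, > 10000 nM. Compound 3 `COc1ccccc1/C=C/C(=O)c1ccc(OC)c2c1OC(C)(C)C=C2` also gives only a limit, > 10000 nM. This is the limit of > 10000 nM in this assay, at which 2 of the 3 values shown sit, so compound 3 has no number to start from.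

Compound 4 `COc1ccc(C(=O)/C=C/c2ccc(O)c(Br)c2)c2c1C=CC(C)(C)O2` carries one change from compound 3: 3-bromo-4-hydroxyphenyl in place of 2-methoxyphenyl on a double-bonded chain carbon bound to a double-bonded chain carbon. The measured steps at this place are an at least 3.8-fold higher number from compound 1 to compound 3 (0.58 log units; beyond the scatter) and an at least 3.8-fold higher number from compound 1 to compound 2 (0.58 log units; beyond the scatter), both beyond the scatter, while a step that the two limits leave unreadable from compound 2 to compound 3 cannot be sized. Only compound 1, at 2610 nM, shows that a group here can bring a number within range, so a modest gain is expected. Another limit remains possible for compound 4.

The expected change is an at least 2.0-fold lower number from compound 3 to compound 4 (0.30 log units; that floor lies within the scatter), toward a stronger inhibitor. The estimate for compound 4 is 5000 nM, with an expected range of 1500 nM to 15000 nM.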

Compound 4, half-maximal inhibitory concentration: > 10000 nM
Compound 4: a limit, no number (the forecaster's own chance of this, stated with the estimate: 35%); middle value at least 2.0-fold (0.30 log units) from the limit.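

In this assay compound 4 gives > 10000 nM as a limit, not a number. Even with a hydrogen-bond donor on the entering group, 3-bromo-4-hydroxyphenyl gives an at least 3.8-fold higher number from compound 1 to compound 4 (0.58 log units; beyond the scatter) and leaves 4-nitrophenyl as the only group at this place with a measured number. The steps to compound 4 from compound 2 and from compound 3 cannot be read, because their values sit at one limit: the limit of > 10000 nM in this assay, at which 3 of the 4 values shown sit.

From the compounds shown here alone, whether the number of compound 1 depends on the nitro group or on the phenyl ring alone stays open. An amine or a carboxylic acid on that phenyl ring would address this.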